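The source may report more compounds than this note shows. Statements on the series, on what has been measured and on what is new or still open speak of the compounds shown alone.

Measured compounds:
compound 1 `CC(C)CCn1nc(-c2cccs2)c(O)c(C2=NS(=O)(=O)c3cc(NS(=O)(=O)C4CC4)ccc3N2)c1=O` — > 1 h
compound 2 `CC(C)=Cc1nn(CCC(C)C)c(=O)c(C2=NS(=O)(=O)c3cc(NS(C)(=O)=O)ccc3N2)c1O` — 0.55 h
compound 3 `CCC(C)(C)Cn1nc(-c2cccs2)c(O)c(C2=NS(=O)(=O)c3cc(NS(C)(=O)=O)ccc3N2)c1=O` — > 1 h

In an in vitro ADME assay on microsomes from liver (Homo sapiens) for metabolic stability, tested at 5 uM (on this read-out lower numbers stand for a shorter-lived compound and higher numbers for a longer-lived compound), compound 3 reaches only the limit of the assay, reported as > 1 h, not a number. Compound 1 also sits at that limit, > 1 h. Compound 2 gives a number in this assay, 0.55 h. So compound 3 stands among the two values that sit at the limit, (the limit of > 1 h in this assay, at which 2 of the 3 values shown sit), and only a limit is known for it.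

Compound 4 `CS(=O)(=O)Nc1ccc2c(c1)S(=O)(=O)N=C(c1c(O)c(-c3cccs3)nn(CCC3CCCC3)c1=O)N2` differs from compound 3 in one place: cyclopentylmethyl in place of 1,1-dimethylpropyl on a saturated chain carbon bound to an aromatic nitrogen. No measured step of this kind is known among these compounds. Compound 4 is expected to stay near compound 3, with a step that the limit leaves unreadable from compound 3 to compound 4 that lies within the usual scatter, so its half-life is estimated at 1.2 h, between 0.5 h and 3 h.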

Compound 4, half-life: > 1 h
Compound 4: no number, only a limit (the forecaster's own chance of this, stated with the estimate: 55%); the middle value is on the limit's open side.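

Compound 4, like compound 3, gives only a limit in this assay, so no step between the two can be read: the limit of > 1 h in this assay, at which 3 of the 4 values shown sit.

The compounds shown leave open how long the half-life of either compound actually is, and whether cyclopentylmethyl and 1,1-dimethylpropyl differ on this read-out.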